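A few compounds are considered here, and "the series" means these few. Any claim that something is new, unique, unknown or untested is made for them only; others in the source may bear on it.

Measured compounds:
Compound 1, `CCc1ccccc1NC(=O)N[C@H](C)c1ccccc1`: 100%
Compound 2, `CC(=O)c1ccccc1NC(=O)N[C@H](C)c1ccccc1`: 95%

Both numbers come from an ADME assay on the whole organism with Oryza sativa as the target, tested at 1 uM; on this read-out lower numbers stand for a stronger effect and higher numbers for a weaker effect at the one concentration tested. On this read-out compound 2 gives 95%, and compound 1 gives 100%, the two lying within the scatter of each other. Among the compounds with values here, the only step among the measured compounds, a number 5 percentage points lower from compound 1 to compound 2 (within the scatter), comes from putting acetyl in place of ethyl on an aromatic carbon, and it did not move the number beyond the scatter.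

Compound 3, `C[C@@H](NC(=O)Nc1ccccc1I)c1ccccc1`, has not yet been measured in this assay. It differs from compound 2 in one place: iodo in place of acetyl on an aromatic carbon. Within the data shown here, that is the same aromatic carbon on which the one measured step took place, so the step from compound 1 to compound 2 is the only guide here, and it was small. With no other evidence, an exchange at this position is expected to leave the read-out essentially where it was, that is a step of a number 2 percentage points higher from compound 2 to compound 3 (within the scatter), with no change beyond the scatter foreseen.

Compound 3 is therefore estimated at 97% in this assay, within a range from 85% to 100%.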

Compound 3, a percentage reported as activity, at one concentration (the size of the read-out at that concentration, not a potency): 100%
Compound 3: the middle estimate sits 3 percentage points below what was measured; low and high end bracket the measured number.
By their numbers in this assay, from the lowest: compounds 2, 1 and 3 (each within the scatter of the next).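

In this assay, iodo in place of acetyl gives a number 5 percentage points higher from compound 2 to compound 3 (within the scatter), and iodo in place of ethyl gives no change at the digits printed from compound 1 to compound 3 (within the scatter), so this aromatic carbon, ortho to a large group, has now held three different groups without the read-out leaving the scatter. The exchange of acetyl for iodo is also a different kind of change from the earlier one: a group of 3 heavy atoms with a double bond and a hydrogen-bond acceptor gives way to a single iodine atom with no hydrogen-bond acceptor, yet the result is still a step within the scatter. No measurement is available that would explain this flat result.

From the compounds shown here alone, it remains open whether any group on this carbon can move the number beyond the scatter, for instance an amine, a carboxylic acid or a longer chain. Going by these compounds, it is also open whether a change elsewhere on the shared core would do so, and a read-out at a single concentration says nothing about potency.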